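The compounds below may be only part of what the source reports. "The series", "measured", "known", "first", "only" and "open" are said of these compounds alone.

The three measured compounds and their read-outs:
- compound 1, `COc1cc(/C=C/C(=O)C2=C(/C=C/c3ccc(O)c(OC)c3)NC(=O)NC2c2ccccc2)ccc1O`, gives 40.2% in a functional assay, with a stated time of 20 min, tested at 50 uM; a higher number here means a stronger effect of the compound at the concentration tested, a lower number a weaker effect
- compound 2, `COc1cc(/C=C/C(=O)C2=C(/C=C/c3ccc(O)c(OC)c3)NC(=O)NC2c2ccc(C)cc2)ccc1O`, gives 46% in this assay
- compound 3, `COc1cc(/C=C/C(=O)C2=C(/C=C/c3ccc(O)c(OC)c3)NC(=O)NC2c2ccc(O)cc2)ccc1O`, gives 90.3% in this assay

Compound 1 stands lowest of the three numbers in this assay. Its nearest neighbour is compound 2, with a number 5.8 percentage points higher from compound 1 to compound 2 (within the scatter), a gap inside the scatter. Its furthest is compound 3, with a number 50.1 percentage points higher from compound 1 to compound 3 (beyond the scatter), a large gap well beyond the scatter. The unmeasured compound 4, `COc1cc(/C=C/C(=O)C2=C(/C=C/c3ccc(O)c(OC)c3)NC(=O)NC2c2ccc(N(C)C)cc2)ccc1O`, differs from compound 1 in one place: dimethylamino in place of hydrogen on an aromatic carbon.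

Among the measured compounds shown here, no measured step carries this exact change, so the expectation rests on the two substitutions at the same position that have been measured. Methyl changed little, hydroxy changed much, and the two groups are themselves separated by a number 44.3 percentage points higher from compound 2 to compound 3 (beyond the scatter). Dimethylamino is a different group from either, and the account leans on that uncertainty.

Compound 4 is therefore expected to give 55% in this assay, in a range from 30% to 85%. That estimate means a step of a number 14.8 percentage points higher from compound 1 to compound 4 (beyond the scatter), which is expected to be modest and upward rather than as large as the hydroxy step.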

Compound 4, a percentage reported as activity, at one concentration (the size of the read-out at that concentration, not a potency): 56%
The estimate for compound 4 lay 1 percentage points below the measured number; low and high end bracket the measured number.
By their numbers in this assay, from the lowest: compounds 1, 2 and 4 (each within the scatter of the next, the first and the last beyond it); then compound 3.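

At this position on the aromatic ring, dimethylamino adds a modest step to the small methyl step and the large hydroxy step in this assay, with a number 15.8 percentage points higher from compound 1 to compound 4 (beyond the scatter). It falls well short of hydroxy, with a number 34.3 percentage points lower from compound 3 to compound 4 (beyond the scatter), and cannot be separated from methyl, with a number 10 percentage points higher from compound 2 to compound 4 (within the scatter), so substitution here does not in itself reproduce the high number of compound 3. No available evidence bears on why these groups give different numbers.

Going by these compounds, it remains open whether a primary amine or a carboxylic acid at this position would come close to hydroxy or stay with methyl and dimethylamino. The compounds shown also leave open whether hydroxy would give a comparable step at another place on the same ring.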